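Selenium for sulfur in the chloro-butynyl side chain

The source may hold more compounds than are shown below. What is called first, only, known or untested is meant among the compounds shown, and "the series" means these compounds.

Measured compounds in a functional assay on SW707 cells (Homo sapiens) for antiproliferative activity, with a stated time of 72 h; a lower number here means a stronger inhibitor, a higher number a weaker inhibitor:
compound 1 `OCC#CCSc1cnc2ccccc2c1SCC#CCCl`: 19.8 ug/mL
compound 2 `CSc1cnc2ccccc2c1SCC#CCCl`: 3.7 ug/mL
compound 3 `C#CCSc1cnc2ccccc2c1SCC#CCCl`: 12.9 ug/mL

Compound 1 carries the highest number of the three; its gap to compound 3 is within the scatter a 1.5-fold lower number from compound 1 to compound 3 (0.19 log units; within the scatter), while the gap to compound 2 lies beyond it a 5.4-fold lower number from compound 1 to compound 2 (0.73 log units; beyond the scatter). Compound 4 `OCC#CCSc1cnc2ccccc2c1[Se]CC#CCCl` differs from compound 1 by a group of 6 heavy atoms (4 carbon, 1 chlorine, 1 selenium; no ring) in place of a group of 6 heavy atoms (4 carbon, 1 sulfur, 1 chlorine; no ring), on an aromatic carbon, on the shared core. Among the compounds with values here, no measured step touches this position: the measured steps of a 5.4-fold lower number from compound 1 to compound 2 (0.73 log units; beyond the scatter) and a 3.5-fold higher number from compound 2 to compound 3 (0.54 log units; beyond the scatter) concern the other sulfur-bound chain. With nothing in this assay bearing on the exchange, no step beyond the scatter is expected. The step to compound 4 is therefore estimated as a 1.2-fold lower number from compound 1 to compound 4 (0.07 log units; within the scatter). For compound 4 the expected value is 17 ug/mL, within 7 ug/mL to 40 ug/mL.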

Compound 4, concentration for 50% inhibition: 3.3 ug/mL
Estimate against measurement, compound 4: 5.2-fold (0.71 log units) above, outside the stated range (below it).
By their numbers in this assay, from the lowest: compounds 4 and 2 (each within the scatter of the next); then compounds 3 and 1 (each within the scatter of the next).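

In this assay, the aromatic carbon opposite the ring nitrogen proves sensitive: selenium in place of sulfur in the chloro-butynyl chain gives a 6.0-fold lower number from compound 1 to compound 4 (0.78 log units; beyond the scatter). The number therefore moves beyond the scatter through this position as well as through the other sulfur-bound chain, even though the exchanged groups match in heavy-atom count. Nothing available accounts for this step.

Still open, as far as these compounds go, is whether the exchange carries over to the other sulfur-bound chains of compound 2 and compound 3. Also open, from the compounds shown here alone, is how an amine linker at this carbon would compare.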